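Methoxy added to the ring of compound 1

The source may report more compounds than this note shows. Statements on the series, on what has been measured and on what is new or still open speak of the compounds shown alone.

Compound 1 (`COc1ccc(C(=O)/C=C/c2ccccc2-c2ccc(F)cc2)cc1OC`) gives 7500 nM in a functional assay on A549 cells (Homo sapiens) for antiproliferative activity, read by sulforhodamine B assay, with a stated time of 48 h (on this read-out lower numbers stand for stronger inhibition and higher numbers for weaker inhibition), and stands within the scatter of compound 2 (`COc1cc(C(=O)/C=C/c2ccccc2-c2ccc(F)cc2)ccc1O`) at 4600 nM with no clear rank between them. Compound 3 (`COc1cc(C(=O)/C=C/c2ccccc2-c2ccc(F)cc2)cc(OC)c1OC`) differs from compound 1 by methoxy in place of hydrogen on an aromatic carbon. Within the data shown here, the only measured step (a 1.6-fold lower number from compound 1 to compound 2 (0.21 log units; within the scatter)) is a different change and gives no sign of a large effect, so no shift beyond the scatter is expected in this assay here. The expected step is small (a 1.4-fold lower number from compound 1 to compound 3 (0.13 log units; within the scatter)). Compound 3 is estimated at 5500 nM with an expected range of 1800 nM to 16000 nM for its measurement.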

Compound 3, half-maximal inhibitory concentration: 2200 nM
Compound 3: middle estimate off by 2.5-fold (0.40 log units), on the high side; measured number inside the range.
By their numbers in this assay, from the lowest: compound 3; then compounds 2 and 1 (each within the scatter of the next).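

In this assay methoxy in place of hydrogen on an aromatic carbon, ortho to a methoxy group, gives a 3.4-fold lower number from compound 1 to compound 3 (0.53 log units; beyond the scatter) and is a modest step. Unlike the within-scatter step a 1.6-fold lower number from compound 1 to compound 2 (0.21 log units; within the scatter) on the same ring, this change clears the scatter, so this ring position responds to substitution. The data offer no explanation for the step. On these data alone, whether the effect is specific to methoxy stays open: fluorine, hydroxy or an amine on this carbon would test that, as would ethoxy for a longer chain.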